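Swapping the carbonyl substituent from compound 2 to compound 3

The source may hold more compounds than are shown below. What is called first, only, known or untested is meant among the compounds shown, and "the series" means these compounds.

In an ADME assay on microsomes from liver (Mus musculus) for metabolic stability, with a stated time of 10 min (a higher number here means that more of the compound is left, a lower number that less of the compound is left), compound 2 `O=C([C@H]1CC[C@H](CO)CC1)N1CC[C@](c2ccc(C(F)(C(F)(F)F)C(F)(F)F)cc2)(S(=O)(=O)c2ccc(F)cc2)C1` gives 63%, the lower of two numbers, and compound 1 `COC[C@]1(C(=O)N2CC[C@](c3ccc(C(F)(C(F)(F)F)C(F)(F)F)cc3)(S(=O)(=O)c3ccc(F)cc3)C2)CC[C@H](C(=O)O)CC1` gives 88%. Compound 3 `O=C(N1CC[C@](c2ccc(C(F)(C(F)(F)F)C(F)(F)F)cc2)(S(=O)(=O)c2ccc(F)cc2)C1)C1(F)CCS(=O)(=O)CC1` has 4-fluoro-1,1-dioxothian-4-yl in place of 4-(hydroxymethyl)cyclohexyl on a carbonyl carbon. Within the data shown here, only one measured step bears on this change, a number 25 percentage points lower from compound 1 to compound 2 (beyond the scatter), and it also concerns the group on the carbonyl carbon. Among the measured compounds shown here, no measured compound carries the entering group, so the direction is uncertain. The expected step is a number 12 percentage points higher from compound 2 to compound 3 (beyond the scatter), upward and smaller than the measured one. For compound 3 the estimated value is 75%, with a range of 55% to 92%.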

Compound 3, percent of the compound remaining: 90%
For compound 3 the middle estimate is 15 percentage points below the measured one; low and high end bracket the measured number.
By their numbers in this assay, from the lowest: compound 2; then compounds 1 and 3 (each within the scatter of the next).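

In this assay, the group on the carbonyl carbon is shown to tolerate a ring with a hetero atom: 4-fluoro-1,1-dioxothian-4-yl in place of 4-(hydroxymethyl)cyclohexyl gives a clear gain (a number 27 percentage points higher from compound 2 to compound 3 (beyond the scatter)). Against 4-carboxy-1-(methoxymethyl)cyclohexyl, the same group gives no readable difference (a number 2 percentage points higher from compound 1 to compound 3 (within the scatter)), so a carboxylic acid is not required at this position for a number of this level. No evidence at hand explains either step.

Still open, as far as these compounds go, is whether the fluorine or the ring sulfur with its two oxygens carries the step. From the compounds shown here alone, how an amine on the carbonyl carbon's ring would read here also remains unknown.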